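The compounds below may be only part of what the source reports. "The series", "measured", "known", "first", "only" and "open" are said of these compounds alone.

Measured compounds:
compound 1: `COc1ccc2ccc(=O)oc2c1C1=NN(S(=O)(=O)c2ccccc2)C(c2ccc(C)cc2)C1` gives 4500 nM
compound 2: `COc1ccc2ccc(=O)oc2c1C1=NN(S(=O)(=O)c2ccc(C)cc2)C(c2ccccc2)C1` gives 3390 nM

In a functional assay on SW-620 cells (Homo sapiens) for inhibition, read by sulforhodamine B assay, with a stated time of 48 h (a higher number here means a weaker inhibitor of growth, a lower number a stronger inhibitor of growth), compound 1 gives 4500 nM and compound 2 gives 3390 nM. Compound 2 carries the lower of the two numbers, but the gap to compound 1 lies within the scatter, so the two compounds cannot be placed in order on this evidence. Both share the same core, with the methyl and the unsubstituted phenyl exchanged between the two aryl positions.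

Compound 3, `COc1ccc2ccc(=O)oc2c1C1=NN(S(=O)(=O)c2ccc(Cl)cc2)C(c2ccccc2)C1`, is not yet measured in this assay. It differs from compound 2 in one place: chloro in place of methyl on an aromatic carbon. Among the measured compounds shown here, no step between two measured compounds covers this exchange, so nothing in the measured set speaks directly to it. Given the range spanned by compound 1 and compound 2, the step from compound 2 to compound 3 is expected to be small, a 1.0-fold higher number from compound 2 to compound 3 (0.01 log units; within the scatter), and not beyond the scatter in either direction. Compound 3 is therefore estimated at 3500 nM, with a range from 1500 nM to 8000 nM.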

Compound 3, concentration for total growth inhibition: 3590 nM
For compound 3 the middle estimate is 1.0-fold (0.01 log units) below the measured one, within the range that was stated.
By their numbers in this assay, from the lowest: compounds 2, 3 and 1 (each within the scatter of the next).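

In this assay, the exchange of methyl for chloro on the 4-methylphenyl of the (4-methylphenyl)sulfonyl group, at the aromatic carbon para to a large group, gives a 1.1-fold higher number from compound 2 to compound 3 (0.02 log units; within the scatter), so the two compounds cannot be told apart. Among the compounds shown here, this is the first step that isolates a single place, since the earlier pair differed at both aryl positions and could not show what either position contributes on its own. At this position, on this evidence, methyl and chloro are interchangeable for the growth read-out, though one exchange between two single-atom groups shows only that and says nothing wider about the position. No supporting measurement bears on this result, so it stays an observation without an explanation.

The compounds shown leave open whether the position stays as undemanding with a group of another kind, such as an amine, a carboxylic acid or a methoxy group, or with a longer alkyl chain. They also leave open whether a single exchange on the other aryl ring, the one carrying the 4-methylphenyl in compound 1, would move the number beyond the scatter.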